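The source may report more compounds than this note shows. Statements on the series, on what has been measured and on what is new or still open speak of the compounds shown alone.

Measured compounds:
compound 1 `Cn1ncc2c(=O)n(-c3ccccc3)c(SC(C)(C)c3ccccc3)nc21`, giving 2200 nM in an assay on isolated protein for inhibition of retinal dehydrogenase 2 (Homo sapiens); on this read-out higher numbers stand for weaker inhibition and lower numbers for stronger inhibition
compound 2 `C[C@@H](Sc1nc2c(cnn2C)c(=O)n1-c1ccccc1)c1ccccc1`, giving 40 nM in this assay

For the measured compounds named here, compound 2 stands at the lowest number of the two measured in this assay; its nearest neighbour is compound 1, and the single measured step is a 55-fold lower number from compound 1 to compound 2 (1.74 log units; beyond the scatter), which is beyond the scatter. That step exchanges a group carrying two methyls on the carbon attached to the sulfur for one carrying a single methyl and a hydrogen there.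

Compound 3 `CCC(Sc1nc2c(cnn2C)c(=O)n1-c1ccccc1)c1ccccc1` is not yet measured. Its change from compound 2 is 1-phenylpropyl in place of 1-phenylethyl on a sulfur. The carbon attached to the sulfur keeps its hydrogen; only the methyl grows to an ethyl. Going by the values given here, the one measured step bears on it only loosely: it shows that the substitution pattern at that carbon matters strongly in this assay, but no measured pair tests a longer chain in place of the methyl. The expectation is therefore a step well short of the measured one, probably towards a somewhat higher number, and possibly none beyond the scatter.

For compound 3 the estimate is 80 nM, within 25 nM to 300 nM, meaning an expected step of a 2.0-fold higher number from compound 2 to compound 3 (0.30 log units; within the scatter).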

Compound 3, half-maximal inhibitory concentration: 179 nM
Beside the measured number, compound 3's estimate is 2.2-fold (0.35 log units) below it, and the stated range covers the measured number.
By their numbers in this assay, from the lowest: compound 2; then compound 3; then compound 1.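

In this assay, the carbon attached to the sulfur responds to the length of the chain as well as to the groups it carries: growing the methyl of 1-phenylethyl to the ethyl of 1-phenylpropyl gives a step beyond the scatter (a 4.5-fold higher number from compound 2 to compound 3 (0.65 log units; beyond the scatter)). The 1-phenylpropyl group still stands well ahead of 1-methyl-1-phenylethyl (a 12-fold lower number from compound 1 to compound 3 (1.09 log units; beyond the scatter)), so across these three compounds, the change that keeps a hydrogen on that carbon outweighs the change from methyl to ethyl. No measured evidence on the origin of either step is available.

Compound 2 has one defined stereocentre and compound 3 has none in its printed structure, so the part of the step that belongs to the ethyl cannot be separated from this difference in stereochemical definition, and the separate mirror-image forms of compound 3 would be needed to settle it. Also open, as far as these compounds go, is whether the trend continues with a longer chain such as propyl, or how the position responds to a cyclopropyl group or to an amine or a carboxylic acid on the chain.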